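Aryl sulfonamide variation on the hexylamine benzyl series

The source may report more compounds than this note shows. Statements on the series, on what has been measured and on what is new or still open speak of the compounds shown alone.

Measured so far:
- compound 1 `Cc1ccc(C)c(S(=O)(=O)NCCCCCCNCc2ccc(Br)cc2)c1`: 12000 nM
- compound 2 `CCCCc1ccc(S(=O)(=O)NCCCCCCNCc2ccc(Br)cc2)cc1`: 5700 nM
- compound 3 `O=S(=O)(NCCCCCCNCc1ccc(Br)cc1)c1c(Cl)cccc1Cl`: 14700 nM

All three share the same chain and bromobenzyl amine and differ only in the aryl group on the sulfonyl sulfur. In a functional assay on MIA PaCa-2 cells (Homo sapiens) for inhibition, read by MTT assay, with a stated time of 72 h (on this read-out higher numbers stand for weaker inhibition of growth and lower numbers for stronger inhibition of growth), compound 3 gives the highest of the three numbers. Among the compounds with values here, its nearest neighbour is compound 1, and the only step with a single change, a 1.2-fold higher number from compound 1 to compound 3 (0.09 log units; within the scatter), is within the scatter. Within the data shown here, compound 2 is the furthest from compound 3; no single-change step is defined between them, but their two values differ by more than the scatter, with compound 2 giving the lower number.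

Compound 4 `O=[N+]([O-])c1ccc(S(=O)(=O)NCCCCCCNCc2ccc(Br)cc2)cc1` is not yet measured. The change from compound 3 is 4-nitrophenyl in place of 2,6-dichlorophenyl on a sulfonyl sulfur. Among the measured compounds shown here, the one step that bears on it is the aryl swap on the same sulfonyl sulfur, a 1.2-fold higher number from compound 1 to compound 3 (0.09 log units; within the scatter), which stayed within the scatter. On that basis no step beyond the scatter is expected from compound 3 to compound 4 in this assay, in either direction. The step expected for compound 4 is a 1.2-fold lower number from compound 3 to compound 4 (0.09 log units; within the scatter). Compound 4 is therefore estimated at 12000 nM, with a range from 5000 nM to 30000 nM.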

Compound 4, concentration for 50% growth inhibition: 9800 nM
Estimate against measurement, compound 4: 1.2-fold (0.09 log units) above, within the range that was stated.
By their numbers in this assay, from the lowest: compounds 2, 4, 1 and 3 (each within the scatter of the next, the first and the last beyond it).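

In this assay, 4-nitrophenyl on a sulfonyl sulfur gives a 1.5-fold lower number from compound 3 to compound 4 (0.18 log units; within the scatter) and a 1.2-fold lower number from compound 1 to compound 4 (0.09 log units; within the scatter), while nitro in place of butyl on an aromatic carbon gives a 1.7-fold higher number from compound 2 to compound 4 (0.24 log units; within the scatter) so all three new steps stay within the scatter. Within the data shown here, this is the first aryl group in the set to carry hydrogen-bond acceptors, 2 against 0 for the 2,6-dichlorophenyl it replaces, and that difference brings no step beyond the scatter at this position. Since compound 4 lies within the scatter of every other compound here, it adds no separation among the aryl groups, and nothing at hand bears on why these numbers lie so close.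

The compounds shown leave open whether a carboxylic acid or an amine in place of nitro on the aromatic carbon would give a step beyond the scatter, which would show whether this position can move the number at all. They also leave open how a longer chain than the hexyl chain, or another halogen in place of the bromine, would read with the aryl group held constant.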